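A few compounds are considered here, and "the series" means these few. Any claim that something is new, unique, unknown or untested is made for them only; others in the source may bear on it.

Among the compounds with values here, compound 2 `CCc1ccc(-c2nnc(COc3cnn(C(C)(C)C)c(=O)c3Cl)o2)cc1` gives 14.5 ug/mL in a functional assay on the whole organism for inhibition, with Mythimna separata as the target, with a stated time of 5 days (on this read-out lower numbers stand for an effect already at smaller amounts and higher numbers for an effect only at larger amounts of compound), and stands highest of the two numbers so far; its nearest neighbour, compound 1 `CC(C)(C)n1ncc(OCc2nnc(-c3cccc(F)c3)o2)c(Cl)c1=O`, gives 7.1 ug/mL. Within the data shown here, the one measured step, a 2.0-fold higher number from compound 1 to compound 2 (0.31 log units; beyond the scatter), concerns an exchange on the same aromatic carbon. Compound 3 `CC(C)(C)n1ncc(OCc2nnc(-c3ccco3)o2)c(Cl)c1=O` is not yet measured; it differs from compound 2 by furan-2-yl in place of 4-ethylphenyl on an aromatic carbon. Among the measured compounds shown here, no measured step carries a furan-2-yl, so the only guide is that one aryl exchange moved the number modestly. For compound 3 a step of a 1.5-fold lower number from compound 2 to compound 3 (0.16 log units; within the scatter) is expected, giving an estimated 10 ug/mL with a range of 4 ug/mL to 28 ug/mL.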

Compound 3, half-maximal effective concentration: > 300 ug/mL
Compound 3: no number, only a limit; the forecaster's own chance of this, stated with the estimate: 5%; middle value at least 30-fold (1.47 log units) away from the limit.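

In this assay, the aromatic carbon on the five-membered ring with 2 nitrogen and 1 oxygen proves far more sensitive than the exchange between 3-fluorophenyl and 4-ethylphenyl suggested: furan-2-yl gives an at least 20-fold higher number from compound 2 to compound 3 (1.31 log units; beyond the scatter) and an at least 42-fold higher number from compound 1 to compound 3 (1.62 log units; beyond the scatter). Compound 3 carries a limit and not a number, so both steps give only a lower bound on the size of the change: the limit of > 300 ug/mL in this assay, at which 1 of the 3 values shown sits.

Still open, as far as these compounds go, is whether the loss follows the smaller ring or its oxygen. Thiophen-2-yl and unsubstituted phenyl at this carbon would separate the two.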